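The source may report more compounds than this note shows. Statements on the series, on what has been measured and on what is new or still open speak of the compounds shown alone.

Measured so far in a functional assay on Bel-7402 cells (Homo sapiens) for inhibition, read by MTT assay, with a stated time of 24 h, tested at 10 ug/mL; a lower number here means less inhibition of growth, a higher number more inhibition of growth at the concentration tested:
compound 1 `CC(=O)SCCC(CCCCC(=O)O)SC(C)=O`: 9.22%
compound 2 `O=C(CCCCC(S)CCS)Nc1ccc(Cl)cc1`: 1.16%
compound 3 `Cc1cccc(NC(=O)CCCCC(S)CCS)c1`: 14.1%

Compound 2 gives 1.16% in this assay. That reading lies within the usual scatter of compound 1 at 9.22%. Compound 3 at 14.1% reads higher than compound 2, and that gap lies beyond the scatter.

The next compound to be tested is compound 4 `COc1ccc(NC(=O)CCCCC(S)CCS)cc1`. It follows from compound 2 by one change: methoxy in place of chloro on an aromatic carbon. In words, this is methoxy in place of chloro on an aromatic carbon, para to a large group.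

Going by the values given here, no pair of measured compounds differs in one place only, so the series offers no measured step to serve as a guide for this change. The expectation rests on the spread alone: compound 2 at 1.16% sits under compound 3 at 14.1%, and a further member is expected to fall between those two readings rather than outside them. The estimated step is a number 6.8 percentage points higher from compound 2 to compound 4 (within the scatter), an expected small rise that stays within the scatter. For compound 4 the expected value in this assay is 8%, with an estimated range from 0% to 20%.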

Compound 4, percent growth inhibition at one concentration: 10.4%
Beside the measured number, compound 4's estimate is 2.4 percentage points below it; low and high end bracket the measured number.
By their numbers in this assay, from the lowest: compounds 2, 1, 4 and 3 (each within the scatter of the next, the first and the last beyond it).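

Going by these compounds alone, the reading in this assay is a number 9.2 percentage points higher from compound 2 to compound 4 (within the scatter) when methoxy stands in place of chloro on an aromatic carbon, para to a large group, and this is the first step that isolates a single place. At this position, the exchange of chloro, with its 1 heavy atom and no hydrogen-bond acceptor, for methoxy, with its 2 heavy atoms and 1 hydrogen-bond acceptor, leaves the reading within what repeated measurements can separate. No supporting data bear on this step, so the series gives no account of it.

This one exchange does not show whether any group at this aromatic carbon can move the percent growth inhibition beyond the scatter, and an amine, a carboxylic acid or a trifluoromethyl group there would test that directly. Also open, as far as these compounds go, is how compounds with these groups would read at other concentrations, since a single concentration gives no full response curve and a reading this close to the scatter cannot rank compound 2 and compound 4.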